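Swapping a methoxy for a trifluoromethyl on the pendant ring

This account rests on a few compounds, and the source may have more. Where it says the series, first, only, none or still open, it means among the compounds named here.

Compound 2 `COc1ccc(CC2c3ccc(OC)cc3CCC2NC(=O)Nc2cccc3cnccc23)cc1` gives 8 nM in an assay on HEK293 cells for displacement of a labelled ligand from transient receptor potential cation channel subfamily V member 1 (Homo sapiens) (a higher number here means a weaker inhibitor, a lower number a stronger inhibitor), the lowest of the two numbers measured. Compound 1 `COc1ccc2c(c1)CCC(NC(=O)Nc1cccc3cnccc13)C2Cc1cccnc1` gives 1540 nM in this assay; the step of a 190-fold lower number from compound 1 to compound 2 (2.28 log units; beyond the scatter) was large. Compound 3 `COc1ccc2c(c1)CCC(NC(=O)Nc1cccc3cnccc13)C2Cc1ccc(C(F)(F)F)cc1` differs from compound 2 by trifluoromethyl in place of methoxy on an aromatic carbon. For the measured compounds named here, no measured step exchanges a methoxy for a trifluoromethyl, so the earlier step gives no direct guide, and a change of any size beyond the scatter cannot be ruled out. Compound 3 is expected to give 20 nM, within 4 nM to 120 nM, an estimated step of a 2.5-fold higher number from compound 2 to compound 3 (0.40 log units; beyond the scatter).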

Compound 3, inhibition constant: 2 nM
Beside the measured number, compound 3's estimate is 10-fold (1.00 log units) above it; measured number below the stated range.
By their numbers in this assay, from the lowest: compound 3; then compound 2; then compound 1.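

In this assay, the methoxy is not required at this position on the pendant ring: trifluoromethyl in its place gives a 4.0-fold lower number from compound 2 to compound 3 (0.60 log units; beyond the scatter). Measured against pyridin-3-yl, 4-(trifluoromethyl)phenyl gives a 770-fold lower number from compound 1 to compound 3 (2.89 log units; beyond the scatter), so the large gain seen with 4-methoxyphenyl does not depend on the methoxy itself. Nothing available explains either step.

Open, as far as these compounds go, is how an amine, a carboxylic acid or a single chlorine would fare at this position. Also open, from the compounds shown here alone, is whether trifluoromethyl would give a similar number elsewhere on the ring.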